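From hydroxy to (2-chlorophenyl)amino on a carbonyl carbon

The source may report more compounds than this note shows. Statements on the series, on what has been measured and on what is new or still open speak of the compounds shown alone.

Measured compounds:
- compound 1 `CC(=O)SCCC(CCCCC(=O)O)SC(C)=O`: 8.03%
- compound 2 `O=C(CCCCC1CCSS1)Nc1ccccc1Cl`: 0.72%
- compound 3 `O=C(CCCCC(S)CCS)Nc1cccc(Cl)c1`: 8.04%

In a functional assay on KB cells (Homo sapiens) for inhibition, read by MTT assay, with a stated time of 24 h, tested at 100 ug/mL (a higher number here means more inhibition of growth at the concentration tested, a lower number less inhibition of growth), compound 1 gives 8.03%. This figure lies within the usual scatter of the other two measurements, so the three compounds cannot be ranked on these numbers.

The next compound is compound 4 `CC(=O)SCCC(CCCCC(=O)Nc1ccccc1Cl)SC(C)=O`, which has (2-chlorophenyl)amino in place of hydroxy on a carbonyl carbon of compound 1: (2-chlorophenyl)amino in place of hydroxy on a carbonyl carbon. Among the measured compounds shown here, no measured pair shows this change on its own. The closest evidence is compound 2, which carries the same (2-chlorophenyl)amino group on a different core and gives 0.72%, within the scatter of compound 1.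

No step beyond the scatter is therefore expected in this assay, and no firm direction can be given. The estimated change is a number 1 percentage points higher from compound 1 to compound 4 (within the scatter). For compound 4 the expected value is 9%, with an estimated range of 1% to 22%.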

Compound 4, percent growth inhibition at one concentration: 6.93%
Compound 4: middle estimate off by 2.1 percentage points, on the high side, within the range that was stated.
By their numbers in this assay, from the lowest: compounds 2, 4, 1 and 3 (each within the scatter of the next).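

In this assay the exchange of hydroxy for (2-chlorophenyl)amino on a carbonyl carbon can now be read on one core, and the step is a number 1.1 percentage points lower from compound 1 to compound 4 (within the scatter) on that core. At this position, therefore, a group with a six-membered aromatic ring in place of hydroxy leaves the result within the scatter, and the change gives no direction up or down. Nothing measured here offers a reason for this outcome.

From the compounds shown here alone, whether a simple amine or a longer chain on this carbonyl carbon would read differently from (2-chlorophenyl)amino remains open. Since all the compounds shown lie within the scatter of their neighbours, it also remains open whether any change at this position can move growth inhibition beyond the scatter in this assay.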